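The compounds below may be only part of what the source reports. "The series", "measured", "known", "first", "only" and "open" are said of these compounds alone.

Compound 1 `O=C(CCCCC[C@H](NC(=O)C1CCNC1=O)C(=O)Nc1ccccc1)NO`: 147 nM
Compound 2 `O=C(CCCCC[C@H](NC(=O)C1C(=O)NCC1c1ccccc1)C(=O)Nc1ccccc1)NO`: 88 nM
Compound 3 `Cc1ccc(NC(=O)[C@H](CCCCCC(=O)NO)NC(=O)[C@H]2CCC(=O)N2)cc1`: 163 nM

Of the compounds shown here, three have been measured in an assay on isolated protein for inhibition of polyamine deacetylase HDAC10 (Homo sapiens), read by fluorescence; on this read-out lower numbers stand for stronger inhibition and higher numbers for weaker inhibition. Compound 1 gives 147 nM, compound 2 gives 88 nM and compound 3 gives 163 nM. Compound 3 has the highest of the three numbers, yet it stays within the scatter of compound 1 and of compound 2, so no order among them can be read from these figures.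

Compound 4 `Cc1ccc(NC(=O)CCCCCCC(=O)NO)cc1` is the next compound. It differs from compound 3 in one place: hydrogen in place of ((5-oxopyrrolidin-2-yl)carbonyl)amino on a saturated chain carbon bound to a carbonyl carbon and a saturated chain carbon. The whole ((5-oxopyrrolidin-2-yl)carbonyl)amino group is cut away, leaving a plain chain with the hydroxamic acid at one end and the anilide at the other.

For the measured compounds named here, only one measured step exists, a 1.7-fold lower number from compound 1 to compound 2 (0.22 log units; within the scatter), and it concerns a phenyl added on a saturated ring carbon inside that very group. Going by the values given here, it says nothing about removing the group altogether, so no measured step bears on the change from compound 3 to compound 4. Among the compounds with values here, because compound 3 gives 163 nM with the group present, and because no compound without it has been measured, the expectation for compound 4 rests on the size of the cut alone: a group of nine heavy atoms with two donors and two acceptors is lost, and a weaker number, meaning a higher value, is expected, with wide uncertainty. Compound 4 is estimated at 700 nM, between 150 nM and 3500 nM, a step of a 4.3-fold higher number from compound 3 to compound 4 (0.63 log units; beyond the scatter).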

Compound 4, half-maximal inhibitory concentration: 649 nM
Estimate against measurement, compound 4: 1.1-fold (0.03 log units) above; the range from low to high includes it.
By their numbers in this assay, from the lowest: compounds 2, 1 and 3 (each within the scatter of the next); then compound 4.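

For the compounds shown here, the cut gives a 4.0-fold higher number from compound 3 to compound 4 (0.60 log units; beyond the scatter) in this assay and is the only step in the set that lies beyond the scatter, since the earlier step, a phenyl added inside the group, stayed within it. It shows that the saturated chain carbon bound to a carbonyl carbon and a saturated chain carbon is a place where the change registers: the number with ((5-oxopyrrolidin-2-yl)carbonyl)amino there is lower than with hydrogen, yet the size of the step is modest and compound 4 still gives a measurable number without the group. The data shown offer no independent measurement that would explain this difference.

The compounds shown leave open which part of the removed group accounts for the step, for instance whether a free amine or a plain acetylamino group on that same carbon would give a number closer to that of compound 3 or to that of compound 4. Going by these compounds alone, it also remains open whether removing the group would give a step of similar size from compound 1 or compound 2, as this single pair is the only comparison of its kind.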